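Moving the chloroacetamide anilide around the benzyl ring

The source may report more compounds than this note shows. Statements on the series, on what has been measured and on what is new or still open speak of the compounds shown alone.

The series shares one core, carried through four compounds. Compound 1 `C/C=C/C(=O)Nc1cccc(Cn2nc(-c3ccc(Oc4ccccc4)cc3)cc2C(=O)O)c1` bears a crotonamide on the benzyl ring and a free acid; compound 2 `CCOC(=O)c1cc(-c2ccc(Oc3ccccc3)cc2)nn1Cc1cccc(NC(=O)CCl)c1` bears a chloroacetamide and an ethyl ester; compound 3 `O=C(CCl)Nc1ccc(Cn2nc(-c3ccc(Oc4ccccc4)cc3)cc2C(=O)O)cc1` bears a chloroacetamide and a free acid. In a functional assay on Z-138 cells (Homo sapiens) for inhibition, read by luminescence and CellTiter-Glo, with a stated time of 72 h (on this read-out higher numbers stand for weaker inhibition and lower numbers for stronger inhibition), compound 1 gives 24100 nM, compound 2 gives 400 nM, and compound 3 gives 1500 nM. Compound 3 thus holds the second highest of the three numbers: compound 2 sits closest with the lower number, compound 1 farthest with the higher.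

Compound 4 `O=C(CCl)Nc1cccc(Cn2nc(-c3ccc(Oc4ccccc4)cc3)cc2C(=O)O)c1` has not been measured. It keeps the chloroacetamide and the free acid of compound 3, but the two structures join the same atoms differently: 3-(((chloromethyl)carbonyl)amino)phenyl in place of 4-(((chloromethyl)carbonyl)amino)phenyl on a saturated chain carbon bound to an aromatic nitrogen. Going by the values given here, no pair of measured compounds differs in exactly this way, so the step cannot be read off directly. Compound 2 shows that a 3-(((chloromethyl)carbonyl)amino)phenyl group is compatible with a low number when the acid is esterified, while compound 3 shows a higher number with the free acid in the other arrangement. On this basis compound 4 is expected to stay close to compound 3 in this assay, with the step of a 1.5-fold lower number from compound 3 to compound 4 (0.18 log units; within the scatter) within or only just beyond the scatter. The estimate for compound 4 is 1000 nM, with a range from 300 nM to 4000 nM.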

Compound 4, half-maximal inhibitory concentration: 9100 nM
Estimate against measurement, compound 4: 9.1-fold (0.96 log units) below, and the stated range ends below it.
By their numbers in this assay, from the lowest: compound 2; then compound 3; then compound 4; then compound 1.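

With the free acid held fixed in this assay, the two chloroacetamide arrangements proved not to be interchangeable: placing 3-(((chloromethyl)carbonyl)amino)phenyl in place of 4-(((chloromethyl)carbonyl)amino)phenyl on a saturated chain carbon bound to an aromatic nitrogen gave a 6.1-fold higher number from compound 3 to compound 4 (0.78 log units; beyond the scatter) and left the 4-(((chloromethyl)carbonyl)amino)phenyl compound with the lower number. With the 3-(((chloromethyl)carbonyl)amino)phenyl group held fixed, hydrogen in place of ethyl on an oxygen next to a carbonyl group gave a 23-fold higher number from compound 2 to compound 4 (1.36 log units; beyond the scatter) as a large step, showing that the low number seen with the ethyl ester does not carry over to the free acid. Chloromethyl in place of prop-1-en-1-yl on a carbonyl carbon gave a 2.6-fold lower number from compound 1 to compound 4 (0.42 log units; beyond the scatter) as a modest step, so the chloroacetamide keeps an advantage over the crotonamide with this free acid and this arrangement.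

No supporting data bear on why any of these steps takes its size or direction. The compounds shown leave open whether an ethyl ester would give a lower number with the 4-(((chloromethyl)carbonyl)amino)phenyl group too, and how a methyl ester, a primary carboxamide or a plain acetamide without chlorine would compare at these places.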